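The source may hold more compounds than are shown below. What is called first, only, known or untested is meant among the compounds shown, and "the series" means these compounds.

In a functional assay on SW480 cells (Homo sapiens) for cytotoxicity, read by sulforhodamine B assay, with a stated time of 48 h (a lower number here means a stronger inhibitor, a higher number a weaker inhibitor), compound 1 (`COc1ccc(/C=C/C(=O)c2ccc(N)c(-c3ccc(F)cc3)c2)cc1`) gives 7230 nM and compound 2 (`O=C(/C=C/c1cccc(Br)c1)c1cccc(-c2cccc(F)c2)c1`) gives 8610 nM. These two numbers lie within the scatter of each other, so compound 2 stands level with compound 1 on the only figures available. Compound 3 (`O=C(/C=C/c1ccc(Cl)cc1)c1cccc(-c2cccc(F)c2)c1`) has 4-chlorophenyl in place of the 3-bromophenyl of compound 2, on a double-bonded chain carbon bound to a double-bonded chain carbon: 4-chlorophenyl in place of 3-bromophenyl on a double-bonded chain carbon bound to a double-bonded chain carbon. Going by the values given here, no measured pair shows a step of this kind, so the data give no direct size for it. In this assay, the expectation therefore starts from compound 2 at 8610 nM, with no direction favoured and no shift beyond the scatter. The expected step is a 1.1-fold lower number from compound 2 to compound 3 (0.03 log units; within the scatter). For compound 3 the estimated value is 8000 nM, with an expected range from 3500 nM to 18000 nM.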

Compound 3, half-maximal inhibitory concentration: 16900 nM
For compound 3 the middle estimate is 2.1-fold (0.32 log units) below the measured one; the measured number falls inside the stated range.
By their numbers in this assay, from the lowest: compounds 1, 2 and 3 (each within the scatter of the next, the first and the last beyond it).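

In this assay the series gains its first pair that differs in one place, and it gives a 2.0-fold higher number from compound 2 to compound 3 (0.29 log units; within the scatter) for 4-chlorophenyl in place of 3-bromophenyl on a double-bonded chain carbon bound to a double-bonded chain carbon. At this position, the exchange of these two groups, which have equal heavy-atom counts and no hydrogen-bond donors or acceptors, is not resolved from the scatter, though the pair changes the halogen and its place on the ring together and so cannot separate the two. No measurement at hand offers an explanation for this result.

Going by these compounds, whether a 3-chlorophenyl or 4-bromophenyl group would separate those two changes remains open. Also open, on these data alone, is whether a carboxylic acid or a dimethylamino group on this ring would give a step beyond the scatter.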